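Chloro to methoxy step on the aryl ring, compound 2 to 3

This account rests on a few compounds, and the source may have more. Where it says the series, first, only, none or still open, it means among the compounds named here.

Measured so far:
compound 1 `C[C@@H](O)CCn1nc2c(Br)c(Br)c(Br)c(Br)c2n1`: 94%
compound 2 `OC(CCn1nc2c(Br)c(Br)c(Br)c(Br)c2n1)c1cccc(Cl)c1`: 70%

In a functional assay on CCRF-CEM cells (Homo sapiens) for antiproliferative activity, read by MTT assay, with a stated time of 48 h, tested at 12.5 uM (on this read-out lower numbers stand for a stronger effect and higher numbers for a weaker effect at the one concentration tested), compound 1 gives 94%. In the same read-out compound 2 gives 70%, the lowest of the two numbers shown; its gap to compound 1 lies beyond the scatter, so compound 2 is the stronger of the two at the single concentration tested. Within the data shown here, the two measured compounds differ in more than one place, so no step between them can be read as the effect of a single change.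

Compound 3 `COc1cccc(C(O)CCn2nc3c(Br)c(Br)c(Br)c(Br)c3n2)c1` has not yet been measured. It differs from compound 2 as follows: methoxy in place of chloro on an aromatic carbon. Nothing in the series shows what such a swap does; both measured compounds carry the same core, and neither carries a methoxy group. Among the measured compounds shown here, with no step of this kind known, the expectation is a step from compound 2 to compound 3 that stays within the usual scatter, a number 5 percentage points higher from compound 2 to compound 3 (within the scatter), in either direction. Compound 3 is therefore estimated at 75%, within 55% to 95%, with the measurement still to come.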

Compound 3, a percentage reported as activity, at one concentration (the size of the read-out at that concentration, not a potency): 96%
Estimate against measurement, compound 3: 21 percentage points below; the measured number lies above the stated range.
By their numbers in this assay, from the lowest: compound 2; then compounds 1 and 3 (each within the scatter of the next).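

In this assay, among these compounds, methoxy in place of chloro on an aromatic carbon gives a number 26 percentage points higher from compound 2 to compound 3 (beyond the scatter), the first step that can be read as a single change, and it shows that the read-out is sensitive to the group at this place on the aryl ring. Compound 3 keeps the aryl ring, the chain and the shared core of compound 2, so the ring alone does not carry the stronger effect of compound 2 at the one concentration tested; in this pair, that effect goes with the 3-chlorophenyl group and not with the 3-methoxyphenyl group. Nothing at hand gives a measured property of either group or any other account of the step.

One pair cannot separate what leaving chloro contributes from what entering methoxy contributes, and it gives no trend across substituents at this place. A bromo, trifluoromethyl or amino group on the same aromatic carbon would show whether the weaker effect is particular to methoxy or whether chloro is the exception.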